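This account rests on a few compounds, and the source may have more. Where it says the series, first, only, none or still open, it means among the compounds named here.

Of the compounds shown here, three from one series have been tested for their ability to slow the growth of a human cervical cancer cell line. Compound 1 `COc1ccc(Cn2cc(CNC(=O)c3cn(-c4ccccc4)nc3-c3ccc(F)cc3)nn2)cc1OC` is the reference point. In a functional assay on HeLa cells (Homo sapiens) for antiproliferative activity, read by sulforhodamine B assay, with a stated time of 48 h (on this read-out higher numbers stand for weaker inhibition of growth and lower numbers for stronger inhibition of growth), compound 1 gives 200 nM. Compound 2 `COc1cc(Cn2cc(CNC(=O)c3cn(-c4ccccc4)nc3-c3ccc(F)cc3)nn2)cc(OC)c1OC` differs from compound 1 in one place only, namely (methoxy in place of hydrogen on an aromatic carbon), and in this assay compound 2 gives 2100 nM, a change of an 11-fold higher number from compound 1 to compound 2 (1.02 log units; beyond the scatter). Compound 3 `COc1ccc(Cn2cc(CNC(=O)c3cn(-c4ccccc4)nc3-c3ccc(Cl)cc3)nn2)cc1` gives 1400 nM in this assay, which is near the number for compound 2 and well apart from the number for compound 1; the difference between the core of compound 3 and the core of compound 1 is not broken down here.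

Compound 4 `COc1ccc(Cn2cc(CNC(=O)c3cn(-c4ccccc4)nc3-c3ccc(Cl)cc3)nn2)cc1OC` has not yet been measured. It differs from compound 3 by methoxy in place of hydrogen on an aromatic carbon. Going by the values given here, this is the same kind of change as the one from compound 1 to compound 2, but not the same: in compound 2 the new group also sits meta to a methoxy group, whereas in compound 4 it does not. The earlier step went toward weaker growth inhibition, yet compound 1, which carries two methoxy groups on that ring, has the strongest number of the three, so the direction for compound 4 is uncertain. The expected step is a 2.0-fold lower number from compound 3 to compound 4 (0.30 log units; within the scatter). Compound 4 is estimated to give 700 nM in this assay, with a range from 150 nM to 3000 nM.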

Compound 4, concentration for 50% growth inhibition: 200 nM
For compound 4 the middle estimate is 3.5-fold (0.54 log units) above the measured one; measured number inside the range.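

Putting methoxy in place of hydrogen gives a 7.0-fold lower number from compound 3 to compound 4 (0.85 log units; beyond the scatter) in this assay, and this does not match the earlier step on the other core: the same change on two cores in this assay, an 11-fold higher number (1.02 log units; beyond the scatter) from compound 1 to compound 2 and a 7.0-fold lower number (0.85 log units; beyond the scatter) from compound 3 to compound 4, 74-fold (1.87 log units) apart, beyond the scatter of two such steps. So in this series the change cannot be carried from one core to another with a fixed size or even a fixed direction, and the step that matters more may be the one that sets the final ring: chloro in place of fluoro, with the 3,4-dimethoxybenzyl group kept, gives no change at the digits printed from compound 1 to compound 4 (within the scatter). What this does not show is which difference separates the two methoxy steps, since they differ in the halogen on the core and also in their starting ring: the step to compound 4 begins from 4-methoxybenzyl, while the step to compound 2 begins from a ring that is already 3,4-dimethoxybenzyl.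

The compounds shown leave open how the fluoro core behaves with a 4-methoxybenzyl group, a comparison that would let both methoxy steps start from the same ring. They also leave open whether a hydroxy group or an amine at the same ring position would follow the methoxy results on either core.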